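Amidine series: chain length on the core, compound 3

A few compounds are considered here, and "the series" means these few. Any claim that something is new, unique, unknown or untested is made for them only; others in the source may bear on it.

Measured in an assay on isolated protein for inhibition of serine protease 1 (Bos taurus); a higher number here means a weaker inhibitor, a lower number a stronger inhibitor:
- compound 1 `CC(=N)N1CCC(Oc2ccc3nc(C)n(Cc4ccc5ccc(C(=N)N)cc5c4)c3c2)CC1` gives 18 nM
- compound 2 `CC(=N)N1CCC(Oc2ccc3c(c2)nc(C(C)C)n3Cc2ccc3ccc(C(=N)N)cc3c2)CC1` gives 16 nM

In this assay compound 1 and compound 2 sit within the usual scatter of each other, so the two numbers give no direction between them. Compound 3 `CCCCc1nc2ccc(OC3CCN(C(C)=N)CC3)cc2n1Cc1ccc2ccc(C(=N)N)cc2c1` is not yet measured. It differs from compound 1 by propyl in place of hydrogen on a saturated chain carbon bound to an aromatic carbon. Among the compounds with values here, no step between measured compounds isolates this change; the nearest comparison, compound 1 against compound 2, shows that a larger group at this position left the number essentially unchanged. The step from compound 1 to compound 3 is therefore expected to be small, a 1.1-fold higher number from compound 1 to compound 3 (0.05 log units; within the scatter), with no direction beyond the scatter. Compound 3 is estimated at 20 nM, within the range 8 nM to 60 nM.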

Compound 3, inhibition constant: 5.7 nM
Beside the measured number, compound 3's estimate is 3.5-fold (0.55 log units) above it; measured number outside the range, below it.
By their numbers in this assay, from the lowest: compound 3; then compounds 2 and 1 (each within the scatter of the next).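

In this assay replacing methyl with butyl on the shared core gives a 3.2-fold lower number from compound 1 to compound 3 (0.50 log units; beyond the scatter) and so shows that this position responds to chain length, with the longer chain lowering the number rather than raising it. Within the data shown here, this is the first step at this position that can be read on its own. No measurement here accounts for the step.

Going by these compounds, whether a pentyl chain lowers the number further remains open. Also open, on these data alone, is how a branched isobutyl chain, a cyclopropyl ring or an amine on the chain would compare with butyl.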